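One Aryl Swap Carried Across Two Cores

This account rests on a few compounds, and the source may have more. Where it says the series, first, only, none or still open, it means among the compounds named here.

Four ureas share a common scaffold and differ in two places. Compound 1 `COc1ccc(NC(=O)Nc2nc(Sc3c[nH]c4ccccc34)cc(N3CCCCC3)n2)cc1` and compound 2 `Cc1ccc(C)c(NC(=O)Nc2nc(Sc3c[nH]c4ccccc34)cc(N3CCCCC3)n2)c1` carry the same core, while compound 3 `Cc1ccc(C)c(NC(=O)Nc2nc(Sc3c[nH]c4ccccc34)cc(N3CCN(Cc4ccccc4)CC3)n2)c1` carries a different one; the difference between the two cores is not broken down here. In a functional assay on A549 cells (Homo sapiens) for inhibition, with a stated time of 72 h (on this read-out lower numbers stand for stronger inhibition and higher numbers for weaker inhibition), compound 2 gives 25400 nM. Compound 1 gives 13500 nM in this assay, a step of a 1.9-fold lower number from compound 2 to compound 1 (0.27 log units; within the scatter), the change being (4-methoxyphenyl in place of 2,5-dimethylphenyl on an amide-type nitrogen). Compound 3 returns only a limit of this assay, > 50000 nM, and so stands at the limit of > 50000 nM in this assay, at which 1 of the 3 values shown sits. Compound 4 `COc1ccc(NC(=O)Nc2nc(Sc3c[nH]c4ccccc34)cc(N3CCN(Cc4ccccc4)CC3)n2)cc1` is not yet measured; it relates to compound 3 exactly as compound 1 relates to compound 2, the same change at the same place: 4-methoxyphenyl in place of 2,5-dimethylphenyl on an amide-type nitrogen. If that change carries over, the step from compound 3 is expected to read about an at least 1.1-fold lower number from compound 3 to compound 4 (0.04 log units; that floor lies within the scatter), resting on a 1.9-fold lower number from compound 2 to compound 1 (0.27 log units; within the scatter). Because compound 3 shows only > 50000 nM, the starting point is not a number, so compound 4 is expected to give about 45000 nM in this assay, between 18000 nM and 120000 nM, and may well return only a limit again.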

Compound 4, half-maximal inhibitory concentration: 42300 nM
For compound 4 the middle estimate is 1.1-fold (0.03 log units) above the measured one; the range from low to high includes it.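

In this assay, 4-methoxyphenyl in place of 2,5-dimethylphenyl on the amide-type nitrogen gives an at least 1.1-fold lower number from compound 3 to compound 4 (0.07 log units; that floor lies within the scatter), a floor that does not by itself establish a real gain on this second core. Set beside the step on the first core, the result shows that the change can be carried onto the second core without any sign of a mismatch, but it does not show that the two steps are the same size: the same change on two cores in this assay, a 1.9-fold lower number (0.27 log units; within the scatter) from compound 2 to compound 1 and an at least 1.1-fold lower number (0.07 log units; that floor lies within the scatter) from compound 3 to compound 4; the limit leaves it open whether they differ Compound 3 stands at a limit and not at a number, so the full size of the new step remains unsettled: the limit of > 50000 nM in this assay, at which 1 of the 4 values shown sits.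

The compounds shown leave open how a carboxylic acid or an amine in place of the methoxy group would read on either core, and whether a longer chain there would behave alike. They also leave open whether the same change reads alike on other cell lines.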